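A few compounds are considered here, and "the series" means these few. Any claim that something is new, unique, unknown or untested is made for them only; others in the source may bear on it.

Compound 1 `Cc1cccc(-n2nncc2CN2C(=O)C3(C(C#N)=C(N)Oc4c3c3nc5ccccc5nc3c3ccccc43)c3ccccc32)c1`: > 50000 nM
Compound 2 `N#CC1=C(N)Oc2c(N)cc3nc4ccccc4nc3c2C12C(=O)N(Cc1cnnn1-c1ccccc1Br)c1ccccc12`: 30700 nM

In a functional assay on MCF7 cells (Homo sapiens) for antiproliferative activity, read by MTT assay, with a stated time of 48 h (a lower number here means a stronger inhibitor, a higher number a weaker inhibitor), compound 1 gives > 50000 nM, a limit of the assay rather than a number (the limit of > 50000 nM in this assay, at which 1 of the 2 values shown sits). Among the measured compounds shown here, compound 2 gives 30700 nM in this assay, the only number among the values shown, and it marks a weak inhibitor. Compound 3 `N#CC1=C(N)Oc2c(N)cc3nc4ccccc4nc3c2C12C(=O)N(Cc1cnnn1-c1ccc(Cl)cc1Cl)c1ccccc12` differs from compound 2 by 2,4-dichlorophenyl in place of 2-bromophenyl on an aromatic nitrogen. For the measured compounds named here, no pair of measured compounds differs in a single place, so there is no measured step to gauge this change against. A step from compound 2 to compound 3 of a 1.2-fold lower number from compound 2 to compound 3 (0.09 log units; within the scatter) is expected, no larger than the scatter. Compound 3 is estimated at 25000 nM, between 10000 nM and 60000 nM.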

Compound 3, half-maximal inhibitory concentration: > 50000 nM
Compound 3: only a limit was reported; the forecaster's own chance of this, stated with the estimate: 30%; middle value at least 2.0-fold (0.30 log units) from the limit.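

Among the compounds shown here, this is the first measured step at this position, on an aromatic nitrogen: in this assay, 2,4-dichlorophenyl in place of 2-bromophenyl gives an at least 1.6-fold higher number from compound 2 to compound 3 (0.21 log units; that floor lies within the scatter). Adding a second halogen to the phenyl ring in this way brings no lower number. Compound 3 gives only a limit of the assay, so its step can be read only as a floor, because the value sits at that limit: the limit of > 50000 nM in this assay, at which 2 of the 3 values shown sit.

As far as these compounds go, whether a plain phenyl, a methoxyphenyl or an aminophenyl here would give a lower number stays open.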